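A few compounds are considered here, and "the series" means these few. Any claim that something is new, unique, unknown or untested is made for them only; others in the source may bear on it.

Working notes on the series. The shared core is that of compound 1 `O=S1(=O)C=C(OCc2ccccc2)C(Cc2ccccc2)(Cc2ccccc2)O1`, which in an ADME assay on HEL cells (Homo sapiens) for cytotoxicity, with a stated time of 3 days (on this read-out lower numbers stand for higher toxicity in this test and higher numbers for lower toxicity in this test), gives 200000 nM. Compound 3 `CCC1(Cc2ccccc2)OS(=O)(=O)C=C1NCc1ccccc1` gives 92000 nM in this assay. Compound 2 `CCC1(Cc2ccccc2)OS(=O)(=O)C=C1OCC#N` gives only a limit in this assay, namely > 200000 nM. On the numbers shown compound 2 therefore stands at the top end with no number of its own. Among the compounds with values here, the single measured step from it, an at least 2.1-fold lower number from compound 2 to compound 3 (0.33 log units; beyond the scatter), is at least modest and rests on that limit (the limit of > 200000 nM in this assay, at which 1 of the 3 values shown sits). Compound 4 `CCC1(Cc2ccccc2)OS(=O)(=O)C=C1OCc1ccc(F)cc1` differs from compound 2 by 4-fluorophenyl in place of cyano on a saturated chain carbon bound to an oxygen on an unsaturated carbon. Within the data shown here, no measured step matches this change; the closest point of comparison is compound 1, which gives 200000 nM. The step of an at least 1.3-fold lower number from compound 2 to compound 4 (0.12 log units; that floor lies within the scatter) is expected to be small, likely none beyond the scatter. Compound 4 is estimated at 150000 nM, within 60000 nM to 300000 nM.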

Compound 4, half-maximal cytotoxic concentration: > 50000 nM
Compound 4: only a limit was reported; the forecaster's own chance of this, stated with the estimate: 40%; the middle value does not contradict the limit.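

Compound 2 and compound 4 both carry only limits in this assay, so the step between them cannot be read. The compounds shown leave open whether 4-fluorophenyl in place of cyano shifts this read-out at all.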